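Compound 4 from compound 3: bromo in place of ethoxy

The compounds below may be only part of what the source reports. "The series", "measured", "known", "first", "only" and "open" are said of these compounds alone.

Three close analogues share one core and differ only in one group on the aromatic ring. Compound 1 `Cc1ccccc1Cc1cnc(N)nc1N` gives 29500 nM in an assay for inhibition of Dihydrofolate reductase (Gallus gallus); a higher number here means a weaker inhibitor, a lower number a stronger inhibitor. Compound 2 `COc1ccccc1Cc1cnc(N)nc1N` gives 28800 nM in this assay. Compound 3 `CCOc1ccccc1Cc1cnc(N)nc1N` gives 24500 nM in this assay. Compound 3 carries the lowest of the three numbers, but the gaps to the other two lie within the scatter: a 1.2-fold lower number from compound 1 to compound 3 (0.08 log units; within the scatter) and a 1.2-fold lower number from compound 2 to compound 3 (0.07 log units; within the scatter), as does a 1.0-fold lower number from compound 1 to compound 2 (0.01 log units; within the scatter). No ordering of the three can be claimed.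

Compound 4 `Nc1ncc(Cc2ccccc2Br)c(N)n1` is not yet measured. The change from compound 3 is bromo in place of ethoxy on an aromatic carbon; the new group sits on an aromatic carbon of a six-membered aromatic ring of carbon only. The measured steps that bear on it are the three exchanges at this same carbon, between methyl, methoxy and ethoxy, each of which left the number within the scatter of the others. None of them involved a halogen, so the step to bromo is not directly covered. With every exchange at this position flat so far, the expectation in this assay is a step within the scatter, a 1.1-fold higher number from compound 3 to compound 4 (0.04 log units; within the scatter). Compound 4 is therefore estimated at 27000 nM, with a range of 9000 nM to 80000 nM.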

Compound 4, inhibition constant: 12300 nM
For compound 4 the middle estimate is 2.2-fold (0.34 log units) above the measured one, within the range that was stated.
By their numbers in this assay, from the lowest: compounds 4, 3, 2 and 1 (each within the scatter of the next, the first and the last beyond it).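

In this assay, going by these compounds alone, this position stops being flat once a halogen enters: bromo is the first group at this aromatic carbon to separate from any other, with a 2.3-fold lower number from compound 2 to compound 4 (0.37 log units; beyond the scatter) and with a 2.4-fold lower number from compound 1 to compound 4 (0.38 log units; beyond the scatter) as modest steps. Against ethoxy the separation does not hold, since a 2.0-fold lower number from compound 3 to compound 4 (0.30 log units; within the scatter) stays within the scatter, so compound 3 and compound 4 cannot be ordered and the claim reaches only methoxy and methyl. The change swaps a group of 3 heavy atoms with one hydrogen-bond acceptor for a single bromine without one, and no measurement at hand explains the steps that follow from it.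

The compounds shown leave open whether the lower number belongs to bromo alone or would be shared by chloro or iodo at this aromatic carbon. They also leave open how an amine, a carboxylic acid or a longer alkoxy chain would compare here, and whether bromo on another carbon of the same ring would keep the step.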